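Swapping an amine for phenyl on a shared indazole-free core

The source may hold more compounds than are shown below. What is called first, only, known or untested is meant among the compounds shown, and "the series" means these compounds.

Measured compounds in an assay on isolated protein for inhibition of tyrosine-protein kinase receptor UFO (Homo sapiens), with a stated time of 1.5 h; a lower number here means a stronger inhibitor, a higher number a weaker inhibitor:
- compound 1, `CN1CCC(CNc2ccc3[nH]nc(-c4cnn(C)c4)c3c2)CC1`: 1850000 nM
- compound 2, `CN1CC[C@@H](Nc2cc3c(-c4cnn(C)c4)n[nH]c3cc2Cl)C1`: 74000 nM
- compound 3, `Cn1cc(-c2n[nH]c3ccc(N[C@@H]4CCNC4)cc23)cn1`: 37000 nM

Compound 3 gives the lowest number of the three. Its nearest neighbour is compound 2, whose value lies within the scatter of compound 3, so the two cannot be ranked against each other. Within the data shown here, compound 1 sits far above, and the single one-place step a 50-fold lower number from compound 1 to compound 3 (1.70 log units; beyond the scatter) shows that exchanging the amine substituent on the shared core can move the number a long way.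

Compound 4, `Cn1cc(-c2n[nH]c3ccc(-c4ccccc4)cc23)cn1`, is not yet measured. It differs from compound 3 in one place: phenyl in place of (pyrrolidin-3-yl)amino on an aromatic carbon. The group that leaves carries the amine that all three measured compounds share in some form; the group that enters carries no such amine.

Among the measured compounds shown here, no measured step removes the amine altogether, so the direction of this change has no direct precedent. For the measured compounds named here, the one step that does touch this position, a 50-fold lower number from compound 1 to compound 3 (1.70 log units; beyond the scatter), was large, which argues that compound 4 could land anywhere across a wide span. The expected step of a 1.6-fold higher number from compound 3 to compound 4 (0.21 log units; within the scatter) is therefore given with broad uncertainty. For compound 4 the estimated value in this assay is 60000 nM, with a likely range from 12000 nM to 300000 nM.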

Compound 4, half-maximal inhibitory concentration: 620 nM
Compound 4: the middle estimate sits 97-fold (1.99 log units) above what was measured, outside the stated range (below it).
By their numbers in this assay, from the lowest: compound 4; then compounds 3 and 2 (each within the scatter of the next); then compound 1.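

Low numbers in this assay do not depend on an amine at this place on the shared core: exchanging (pyrrolidin-3-yl)amino for phenyl gives a 60-fold lower number from compound 3 to compound 4 (1.78 log units; beyond the scatter). Until now, every measured compound carried an amine here, so the earlier values could say nothing about a carbon-only ring in this spot. The two groups each count 6 heavy atoms, so this large step comes with a change in the kind of group and not in its number of heavy atoms, but no measurement here explains the shift.

The step changes two things together, the amine nitrogen attached to the core and the ring itself, so the compounds shown cannot say which of the two goes with the lower number; a phenylamino group at this place would pull the two apart, and a cyclohexyl ring would test whether the phenyl ring's aromatic character counts. How far the result extends to other rings is also open, since a pyridine ring or a phenyl ring bearing a fluorine or a methoxy group does not appear among these compounds.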